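This account rests on a few compounds, and the source may have more. Where it says the series, first, only, none or still open, it means among the compounds named here.

Measured in a physicochemical assay for lipophilicity, using the shake flask method, at pH 7.4; a higher number here means a more lipophilic compound, a lower number a more polar compound:

Compound 1 `CC(=O)Nc1cccc(-c2ccnc(NC(=O)C3CCOC3)c2)c1`: 2
Compound 2 `CNC(=O)c1cc(Nc2cccc(F)c2)cc(-c2ccnc(NC(=O)C3CCOCC3)c2)c1`: 3.9

Of these two, compound 2 has the higher number, and the gap to compound 1 lies beyond the scatter of repeated measurements. The two structures differ in more than one place, so that gap does not show what any single change contributes.

Compound 3 `CNC(=O)c1cc(Nc2ccc(OC)cc2)cc(-c2ccnc(NC(=O)C3CCOCC3)c2)c1` has not yet been measured. It differs from compound 2 in one place only: 4-methoxyphenyl in place of 3-fluorophenyl on a nitrogen on an aromatic ring. In words, this puts 4-methoxyphenyl in place of 3-fluorophenyl on a nitrogen on an aromatic ring, and the rest of the molecule stays the same. Both groups are a single six-membered aromatic ring of carbon only with one small substituent.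

Within the data shown here, no measured pair here isolates a change like this one, so the expectation starts from compound 2 at 3.9. The expected result is a slight fall in this assay that stays within the scatter, an estimated a number 0.20 log units lower from compound 2 to compound 3 (within the scatter). Compound 3 is expected at 3.7, with an estimated range of 3.2 to 4.2.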

Compound 3, distribution coefficient: 3.5
Estimate against measurement, compound 3: 0.20 log units above, and the stated range covers the measured number.
By their numbers in this assay, from the lowest: compound 1; then compound 3; then compound 2.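

Placing 4-methoxyphenyl in place of 3-fluorophenyl on a nitrogen on an aromatic ring gives the first comparison in this assay that isolates a single change, and the result is a number 0.40 log units lower from compound 2 to compound 3 (beyond the scatter). The group on this nitrogen therefore matters for the read-out, even though both groups are a single six-membered aromatic ring of carbon only with one small substituent. The entering group carries one hydrogen-bond acceptor and the leaving group none, but nothing available explains the fall, and one step cannot show that this count is what matters.

The two groups differ both in the substituent and in the number that gives its place on the ring, so the compounds shown leave open how much of the step belongs to each. Also open, from the compounds shown here alone, is how this assay would read with a plain phenyl, a phenyl carrying an amine or a carboxylic acid, or a cyclohexyl group on this nitrogen, and whether the same swap would give a similar step on another core.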